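The source may hold more compounds than are shown below. What is called first, only, known or untested is meant among the compounds shown, and "the series" means these compounds.

Measured compounds:
Compound 1 `O=C(c1ccccc1F)N(/N=N/c1ccc([N+](=O)[O-])cc1Br)c1ccc([N+](=O)[O-])cc1Br` — in a functional assay on HeLa cells (Homo sapiens) for cytotoxicity, read by MTT assay, with a stated time of 72 h (on this read-out higher numbers stand for weaker inhibition and lower numbers for stronger inhibition), compound 1 gives 1200 nM.
Compound 2 `O=C(c1ccccc1C(F)(F)F)N(/N=N/c1ccc([N+](=O)[O-])cc1Br)c1ccc([N+](=O)[O-])cc1Br` — in this assay compound 2 gives 13300 nM.
Compound 3 `O=C(c1ccccc1F)N(/N=N/c1ccc([N+](=O)[O-])cc1Cl)c1ccc([N+](=O)[O-])cc1Cl` — in this assay compound 3 gives 2350 nM.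

Compound 2 differs from compound 1 by trifluoromethyl in place of fluoro on an aromatic carbon, and that change produced an 11-fold higher number from compound 1 to compound 2 (1.04 log units; beyond the scatter). Compound 3 carries a different core from compound 1; the difference between the two cores is not broken down here, and the two values lie within the scatter of each other. Compound 4 `O=C(c1ccccc1C(F)(F)F)N(/N=N/c1ccc([N+](=O)[O-])cc1Cl)c1ccc([N+](=O)[O-])cc1Cl` stands to compound 3 as compound 2 stands to compound 1: trifluoromethyl in place of fluoro on an aromatic carbon, at a place described in the same words, so it is the same change. Because the earlier step of an 11-fold higher number from compound 1 to compound 2 (1.04 log units; beyond the scatter) was large, a step of similar size is expected here. Compound 4 is therefore expected to give 22000 nM in this assay, a step of a 9.4-fold higher number from compound 3 to compound 4 (0.97 log units; beyond the scatter), with a likely range from 7000 nM to 60000 nM.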

Compound 4, half-maximal inhibitory concentration: 10600 nM
Estimate against measurement, compound 4: 2.1-fold (0.32 log units) above; low and high end bracket the measured number.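

In this assay, putting 2-(trifluoromethyl)phenyl in place of 2-fluorophenyl again gave a higher number, with a 4.5-fold higher number from compound 3 to compound 4 (0.65 log units; beyond the scatter). The change thus went the same way on both cores, and the two steps cannot be told apart: the same change on two cores in this assay, an 11-fold higher number (1.04 log units; beyond the scatter) from compound 1 to compound 2 and a 4.5-fold higher number (0.65 log units; beyond the scatter) from compound 3 to compound 4, 2.5-fold (0.39 log units) apart, within the scatter of two such steps. For the compounds shown here, this shows that the direction and rough size of the step carried over between these two cores, but with only two pairs it does not show that the change would carry to any other core.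

The compounds shown leave open what other groups would do on this aromatic carbon, such as an amine or a carboxylic acid in place of fluoro or trifluoromethyl.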